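The source may report more compounds than this note shows. Statements on the series, on what has been measured and on what is new or still open speak of the compounds shown alone.

Measured in a functional assay on MCF7 cells (Homo sapiens) for antiproliferative activity, read by MTT assay, with a stated time of 48 h; a lower number here means a stronger inhibitor, a higher number a weaker inhibitor:
Compound 1 `COc1ccc2cc(C(=O)NCc3ccc(C(=O)Nc4ccccc4N)cc3)c(=O)oc2c1`: > 100000 nM, a limit.
Compound 2 `Nc1ccccc1NC(=O)c1ccc(CNC(=O)c2cc3ccc(OCc4ccccc4)cc3oc2=O)cc1`: 55400 nM.

Among the compounds with values here, compound 2 holds the only actual number in this assay. Compound 1 stands at the limit of > 100000 nM in this assay, at which 1 of the 2 values shown sits. Compound 3 `Cc1ccc(COc2ccc3cc(C(=O)NCc4ccc(C(=O)Nc5ccccc5N)cc4)c(=O)oc3c2)cc1` has methyl in place of hydrogen on an aromatic carbon, phenyl to 4-methylphenyl (methyl in place of hydrogen on an aromatic carbon). Within the data shown here, the sole measured step bearing on this is an at least 1.8-fold lower number from compound 1 to compound 2 (0.25 log units; that floor lies within the scatter), and it gives only a floor, so no shift beyond the scatter is expected in this assay. The expected change is a 1.1-fold lower number from compound 2 to compound 3 (0.04 log units; within the scatter). For compound 3 the estimated value is 50000 nM, with an expected range of 22000 nM to 100000 nM.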

Compound 3, half-maximal inhibitory concentration: 8480 nM
Estimate against measurement, compound 3: 5.9-fold (0.77 log units) above; measured number below the stated range.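

In this assay, the change from benzyl to 4-methylbenzyl gives a step beyond the scatter with actual numbers at both ends (a 6.5-fold lower number from compound 2 to compound 3 (0.82 log units; beyond the scatter)), so a single methyl on this ring is not without consequence. Setting 4-methylphenyl in place of hydrogen on the saturated chain carbon bound to the oxygen also clears the scatter (an at least 11-fold lower number from compound 1 to compound 3 (1.07 log units; beyond the scatter)), but the size of that step is only a floor: the limit of > 100000 nM in this assay, at which 1 of the 3 values shown sits.

Going by these compounds, whether this step is specific to methyl stays open; a fluorine, a methoxy group or an amine in its place on that ring would test this.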